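Carbamate ester variation on a shared core, compound 4 pending

The source may report more compounds than this note shows. Statements on the series, on what has been measured and on what is new or still open speak of the compounds shown alone.

Measured so far:
compound 1 `CC(C)C(=O)OCOC(=O)N1CCN(C(=O)c2nc(Nc3cc(C4CC4)[nH]n3)c3cc(Cl)ccc3n2)C[C@H]1C` gives 51.6% in an assay for inhibition of serine/threonine-protein kinase PAK 4 (Homo sapiens), read by FRET and Z'-LYTE, with a stated time of 60 min, tested at 5 uM, in the presence of a further agent that is not named here; on this read-out higher numbers stand for a stronger effect at the one concentration tested and lower numbers for a weaker effect
compound 2 `CCCCCOC(=O)N1CCN(C(=O)c2nc(Nc3cc(C4CC4)[nH]n3)c3cc(Cl)ccc3n2)C[C@H]1C` gives 12.6% in this assay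
compound 3 `COC(=O)N1CCN(C(=O)c2nc(Nc3cc(C4CC4)[nH]n3)c3cc(Cl)ccc3n2)C[C@H]1C` gives 89.6% in this assay

Compound 3 stands highest of the three numbers in this assay; compound 1 is nearest and compound 2 furthest, both gaps beyond the scatter. Compound 4 `CC(OC(=O)C(C)C)OC(=O)N1CCN(C(=O)c2nc(Nc3cc(C4CC4)[nH]n3)c3cc(Cl)ccc3n2)C[C@H]1C` differs from compound 3 by 1-((isopropylcarbonyl)oxy)ethyl in place of methyl on an oxygen next to a carbonyl group. The measured steps that bear on this change both run towards compound 3: a number 38 percentage points higher from compound 1 to compound 3 (beyond the scatter) and a number 77 percentage points higher from compound 2 to compound 3 (beyond the scatter). Within these three compounds, every enlargement of the group on that oxygen goes with a lower number, and the added (isopropylcarbonyl)oxy unit in compound 1 alone already costs a large share. Compound 4 carries that same unit plus one further carbon, so a large downward step in this assay is expected, beyond the scatter. For compound 4 the estimate is 42%, with a range from 15% to 65%. The expected step is a number 47.6 percentage points lower from compound 3 to compound 4 (beyond the scatter).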

Compound 4, a percentage reported as inhibition, at one concentration (the size of the read-out at that concentration, not a potency): 25.8%
Compound 4: the middle estimate sits 16.2 percentage points above what was measured; the measured number falls inside the stated range.
By their numbers in this assay, from the lowest: compound 2; then compound 4; then compound 1; then compound 3.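

In this assay, 1-((isopropylcarbonyl)oxy)ethyl in place of methyl on an oxygen next to a carbonyl group gives a number 63.8 percentage points lower from compound 3 to compound 4 (beyond the scatter) and confirms that this position tolerates the larger group poorly, while the single added methyl gives a number 25.8 percentage points lower from compound 1 to compound 4 (beyond the scatter) and shows that even the chain carbon bound to two oxygens is sensitive to a small change. The pentyl chain still gives the lowest number, with a number 13.2 percentage points higher from compound 2 to compound 4 (beyond the scatter) showing that the read-out does not simply follow the size of the group, and compound 1 and compound 4 both go against such a trend. No measurement shown explains these steps and the reading stays descriptive. Open, from the compounds shown here alone, is where ethyl or isopropyl on this oxygen would fall relative to methyl and pentyl. Also open, going by these compounds, is how a chain ending in an amine or a carboxylic acid would read here.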